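Spiro-oxindole series: triazole aryl swap at the limit

This account rests on a few compounds, and the source may have more. Where it says the series, first, only, none or still open, it means among the compounds named here.

Measured so far:
compound 1 `Cc1ccc(Cl)cc1-n1nncc1CN1C(=O)C2(C(C#N)=C(N)Oc3c2c2nc4ccccc4nc2c2ccccc32)c2ccccc21`: > 50000 nM
compound 2 `N#CC1=C(N)Oc2c(c3nc4ccccc4nc3c3ccccc23)C12C(=O)N(Cc1cnnn1-c1ccc(F)c(Cl)c1)c1ccccc12`: > 50000 nM
compound 3 `Cc1ccc(Cl)cc1-n1nncc1CN1C(=O)C2(C(C#N)=C(N)Oc3c(N)cc4nc5ccccc5nc4c32)c2ccccc21`: 37200 nM

All values come from a functional assay on HCT-116 cells (Homo sapiens) for antiproliferative activity, read by MTT assay, with a stated time of 48 h; on this read-out lower numbers stand for stronger inhibition and higher numbers for weaker inhibition. Compound 1 gives > 50000 nM, which is a limit of the assay and not a number. Compound 2 gives > 50000 nM, likewise a limit and not a number. Going by the values given here, compound 3 is the only member with a measured number, giving 37200 nM in this assay.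

The change from compound 1 to compound 2 is 3-chloro-4-fluorophenyl in place of 5-chloro-2-methylphenyl on an aromatic nitrogen. Its step, a step that the two limits leave unreadable from compound 1 to compound 2, cannot be read because the limit of > 50000 nM in this assay, at which 2 of the 3 values shown sit, covers both ends of it. How the core of compound 3 differs from the core of compound 1 is not broken down here.

Compound 4 `N#CC1=C(N)Oc2c(N)cc3nc4ccccc4nc3c2C12C(=O)N(Cc1cnnn1-c1ccc(F)c(Cl)c1)c1ccccc12` is the unmeasured partner of compound 3, carrying the same kind of change: 3-chloro-4-fluorophenyl in place of 5-chloro-2-methylphenyl on an aromatic nitrogen. The place lines for the two changes agree word for word, so the change is the same one made on a different core. Among the compounds with values here, because the only prior instance of it is a step that the two limits leave unreadable from compound 1 to compound 2 and that step is unreadable, no direction can be taken from it. What remains is the starting value of compound 3 at 37200 nM.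

The step from compound 3 to compound 4 is expected to be a 1.1-fold higher number from compound 3 to compound 4 (0.03 log units; within the scatter), with wide uncertainty. Compound 4 is estimated at 40000 nM, between 15000 nM and 100000 nM, and a report of only a limit is quite possible.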

Compound 4, half-maximal inhibitory concentration: > 50000 nM
Compound 4 ended at the assay's limit; the forecaster's own chance of this, stated with the estimate: 45%; at least 1.2-fold (0.09 log units) between middle value and limit.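

On the core of compound 3, putting 3-chloro-4-fluorophenyl in place of 5-chloro-2-methylphenyl on the aromatic nitrogen gives in this assay an at least 1.3-fold higher number from compound 3 to compound 4 (0.12 log units; that floor lies within the scatter), and as that floor lies within the scatter, it does not by itself establish a real loss of activity. Compound 4 gives > 50000 nM, which is a limit of the assay and not a number. The same change on the core of compound 1 cannot be read, so neither core gives a full size for the change and nothing shows whether its effect carries from one core to the other: the limit of > 50000 nM in this assay, at which 3 of the 4 values shown sit.

Open, on these data alone, is whether a different kind of group on that aromatic nitrogen, such as an amine, a carboxylic acid or a longer chain, would bring either core to a measurable value in this assay. Going by these compounds alone, compound 3 remains the only member with a measured number, so how this change behaves away from the limit also stays open.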